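The compounds below may be only part of what the source reports. "The series", "measured", "known", "first", "only" and "open" are said of these compounds alone.

Compound 1, drawn as `C[C@@H](NC(=O)Nc1cccc(Cl)c1)c1ccccc1`, is the starting point of this small series, and in an ADME assay on the whole organism with Oryza sativa as the target, tested at 10 uM (a higher number here means a weaker effect of the compound at the concentration tested, a lower number a stronger effect), compound 1 gives 83%. Its stereoisomer compound 2, `C[C@H](NC(=O)Nc1cccc(Cl)c1)c1ccccc1`, gives 103% in this assay. The two compounds differ only in the configuration of one centre, described as the two compounds have the same atoms and bonds and differ only in configuration as drawn: 1 of 1 stereo elements differ; a stereocentre at a saturated chain carbon is drawn S in compound 2 and R in compound 1, and the measured step is a number 20 percentage points higher from compound 1 to compound 2 (beyond the scatter); that this step appears at all is tied to the fact that compounds 1 and 2 differ only in the configuration as drawn, since the two compounds share every atom and bond.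

Compound 3, `C[C@H](NC(=O)Nc1cccc(Cl)c1Cl)c1ccccc1`, carries a further substituent on the aromatic ring of compound 2. The change is chloro in place of hydrogen on an aromatic carbon, and in this assay compound 3 gives 101%, so the step is a number 2 percentage points lower from compound 2 to compound 3 (within the scatter).

The unmeasured compound 4, `C[C@@H](NC(=O)Nc1cc(Cl)cc(Cl)c1)c1ccccc1`, is built on the core of compound 1 rather than that of compound 2. The change from compound 1 is chloro in place of hydrogen on an aromatic carbon. Among the compounds with values here, it is the same kind of change as the one between compound 2 and compound 3, but not the same change: in compound 3 the entering chloro sits ortho to a chloro group and ortho to a large group, whereas in compound 4 it sits meta to a chloro group and meta to a large group.

For this assay, compound 4 is expected to give 80%, within a range of 65% to 95%. The expected step is a number 3 percentage points lower from compound 1 to compound 4 (within the scatter), resting on the observation that the comparable step in the other core was a number 2 percentage points lower from compound 2 to compound 3 (within the scatter), so compound 4 is estimated to stay close to the value of compound 1.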

Compound 4, a percentage reported as activity, at one concentration (the size of the read-out at that concentration, not a potency): 99%
Beside the measured number, compound 4's estimate is 19 percentage points below it; the whole stated range lies below it.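

In this assay, the chloro change on the core of compound 1 gives a clear step, a number 16 percentage points higher from compound 1 to compound 4 (beyond the scatter), and this step does not match the one seen on the other core: the same change on two cores in this assay, a number 2 percentage points lower (within the scatter) from compound 2 to compound 3 and a number 16 percentage points higher (beyond the scatter) from compound 1 to compound 4, 18 percentage points apart, beyond the scatter of two such steps This shows that, within these compounds, the result of placing a chloro on one core cannot simply be carried over to the other, so the step on one core says little about the step on the other. It does not show what separates the two steps, since the cores differ in the configuration of the stereocentre and the entering chloro also sits in a different place on the ring, meta to a chloro group and meta to a large group in compound 4, and this single pair of steps cannot tell these two differences apart.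

The compounds shown leave open how the chloro change would read if it sat in the same place on both cores. They also leave open how a fluoro, a methyl or a methoxy group would read in that place on the core of compound 1.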